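The compounds below may be only part of what the source reports. "The series", "measured", "known", "first", "only" and "open" are said of these compounds alone.

Of the compounds shown here, two built on a shared core have been measured in a functional assay on M14 cells (Homo sapiens) for inhibition, read by sulforhodamine B assay, with a stated time of 48 h; on this read-out higher numbers stand for weaker inhibition of growth and lower numbers for stronger inhibition of growth. Compound 1 `Cc1ccc(NC(=O)/C=C/c2ccccc2)c(C(N)=O)c1` gives 2350 nM, and compound 2 `NC(=O)c1cc(Br)ccc1NC(=O)/C=C/c1ccccc1` gives 482 nM, the lower of the two numbers. Compound 3 `NC(=O)c1cc(I)ccc1NC(=O)/C=C/c1ccccc1` alters compound 2 at a single place: iodo in place of bromo on an aromatic carbon. In words, this is iodo in place of bromo on an aromatic carbon. Within the data shown here, only one measured step bears on this place: a 4.9-fold lower number from compound 1 to compound 2 (0.69 log units; beyond the scatter), which is modest but beyond the scatter. Among the measured compounds shown here, that step replaced methyl with bromo, whereas the new change swaps one halogen for another, and no measured step shows such a swap. Only a small change is therefore expected in this assay, with no firm direction. The estimated step is a 1.2-fold lower number from compound 2 to compound 3 (0.08 log units; within the scatter), expected to stay within the scatter. Compound 3 is expected to give about 400 nM, with an estimated range of 160 nM to 1000 nM.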

Compound 3, concentration for 50% growth inhibition: 429 nM
The estimate for compound 3 lay 1.1-fold (0.03 log units) below the measured number, and the stated range covers the measured number.
By their numbers in this assay, from the lowest: compounds 3 and 2 (each within the scatter of the next); then compound 1.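

In this assay, iodo in place of bromo gives a 1.1-fold lower number from compound 2 to compound 3 (0.05 log units; within the scatter), so at this place, para to a large group and meta to a carbamoyl group, the two halogens cannot be told apart. The drop in the number seen on leaving methyl is also not confined to bromo, since iodo in place of methyl gives a 5.5-fold lower number from compound 1 to compound 3 (0.74 log units; beyond the scatter). Nothing on hand explains why these two halogens match here or why both stand apart from methyl. As far as these compounds go, it remains open whether chloro or fluoro at this place would stay with bromo and iodo or fall nearer to methyl, and whether a halogen is needed at all, which a nitrile or a methoxy group could test. Also open, from the compounds shown here alone, is whether the match between bromo and iodo would persist with a carboxylic acid in place of the carbamoyl group.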